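This account rests on a few compounds, and the source may have more. Where it says the series, first, only, none or still open, it means among the compounds named here.

Measured in a functional assay on SMMC-7721 cells (Homo sapiens) for antiproliferative activity, read by CCK-8 assay, with a stated time of 72 h; a lower number here means a stronger inhibitor, a higher number a weaker inhibitor:
compound 1 `Nc1ccccc1NC(=O)c1ccc(CSC(=S)N2CCN(c3ccccc3)CC2)cc1`: 2860 nM
compound 2 `Nc1ccccc1NC(=O)c1ccc(CSC(=S)N2CCc3ccccc32)cc1`: 3040 nM
compound 3 `Nc1ccccc1NC(=O)c1ccc(CSC(=S)N2CCN(c3ccc(F)cc3)CC2)cc1`: > 32000 nM, a limit of the assay

Going by the values given here, compound 2 and compound 1 lie within the scatter of each other, and they hold the only two true numbers in this set. Compound 4 `Nc1ccccc1NC(=O)c1ccc(CSC(=S)N2CCc3cc(Cl)ccc32)cc1` differs from compound 2 by one change: chloro in place of hydrogen on an aromatic carbon. Among the compounds with values here, only one measured step bears on it, a large one elsewhere in the structure and with fluoro rather than chloro: an at least 11-fold higher number from compound 1 to compound 3 (1.04 log units; beyond the scatter). On that single precedent, a move towards a higher number in this assay is expected, though a smaller one, and the expected step is a 2.0-fold higher number from compound 2 to compound 4 (0.30 log units; within the scatter). For compound 4 the estimate is 6000 nM, with an expected range of 1800 nM to 25000 nM.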

Compound 4, half-maximal inhibitory concentration: 1880 nM
Beside the measured number, compound 4's estimate is 3.2-fold (0.50 log units) above it; the measured number falls inside the stated range.
By their numbers in this assay, from the lowest: compounds 4, 1 and 2 (each within the scatter of the next). At a limit, above all of these: compound 3.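

In this assay, chloro on this aromatic carbon of the 2,3-dihydro-1H-indol-1-yl group costs nothing measurable, the step being a 1.6-fold lower number from compound 2 to compound 4 (0.21 log units; within the scatter). A halogen on an aromatic carbon therefore does not by itself abolish activity in this series, and this position accepts chloro. Compound 3, with its fluoro on another ring, remains a limit and not a number: the limit of > 32000 nM in this assay, at which 1 of the 4 values shown sits.

As far as these compounds go, whether this position also accepts a methoxy group, an amine or a carboxylic acid stays open. So does the effect of fluoro here, or of chloro on the phenyl ring of compound 1.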